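Swapping the Amide Tail for a Benzyl Ether

A few compounds are considered here, and "the series" means these few. Any claim that something is new, unique, unknown or untested is made for them only; others in the source may bear on it.

Among the measured compounds shown here, compound 1 `CC(C)c1onc(-c2c(Cl)cccc2Cl)c1COc1ccc(N(C)C(=O)c2ccc(C(=O)O)cc2)c(C(F)(F)F)n1` is the only compound here with a reported number in a functional assay on HEK293 cells for agonist activity at Bile acid receptor (Homo sapiens); on this read-out lower numbers stand for smaller maximal responses and higher numbers for larger maximal responses; in this assay compound 1 gives 36%. Compound 2 `Cc1cc(C(F)(F)F)cc(OCc2c(-c3c(Cl)cccc3Cl)noc2C(C)C)n1` was also tested in this assay, and compound 2 gives "not active" (no number reported), so no number stands beside it. Compound 3 `CC(C)c1onc(-c2c(Cl)cccc2Cl)c1COc1ccc(N(C)Cc2ccc(OCCO)cc2)c(C(F)(F)F)n1` has not been measured yet. It shares the core of compound 1 and differs from it in one place: 4-(2-hydroxyethoxy)benzyl in place of (4-carboxyphenyl)carbonyl on a nitrogen on an aromatic ring. For the measured compounds named here, no measured pair shows a step of this kind, so the direction of the change can only be guessed. The incoming group is of similar size to the departing one, and the expectation is for a step no larger than the scatter, slightly downward at most. Compound 3 is therefore estimated to give 30% in this assay, with a range from 5% to 60%, which means an expected step of a number 6 percentage points lower from compound 1 to compound 3 (within the scatter).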

Compound 3, largest response reached (reported as efficacy), in percent of the reference or control that the assay uses: 43%
Estimate against measurement, compound 3: 13 percentage points below; the measured number falls inside the stated range.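

On the nitrogen on an aromatic ring, 4-(2-hydroxyethoxy)benzyl can stand in for (4-carboxyphenyl)carbonyl with no clear shift in this assay: the swap brings a number 7 percentage points higher from compound 1 to compound 3 (within the scatter). For this pair, then, a measurable response does not require the carboxylic acid or the carbonyl attached to that nitrogen, since compound 3 has neither and still gives a number. No measurement shown explains why the two groups give responses within the usual scatter of each other.

Going by these compounds, what remains open is which part of the new group matters: a plain benzyl would test the need for the 2-hydroxyethoxy chain at all. An amine at the end of that chain, or a longer chain, would show whether the response in this assay can move beyond the scatter.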